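This account rests on a few compounds, and the source may have more. Where it says the series, first, only, none or still open, it means among the compounds named here.

Three close analogues share one core and differ only in the aryl group on an amide-type nitrogen of a urea. Compound 1 `COc1ccccc1NC(=O)Nc1cccc(CNc2ncnc3ccccc23)c1` carries a 2-methoxyphenyl there, and in a functional assay on A549 cells (Homo sapiens) for antiproliferative activity, read by MTT assay (on this read-out lower numbers stand for stronger inhibition and higher numbers for weaker inhibition), compound 1 gives 30800 nM. Compound 2 `COc1ccc(NC(=O)Nc2cccc(CNc3ncnc4ccccc34)c2)cc1` carries a 4-methoxyphenyl; in this assay compound 2 gives 29300 nM, a step of a 1.1-fold lower number from compound 1 to compound 2 (0.02 log units; within the scatter). Compound 3 `O=C(Nc1cccc(Cl)c1)Nc1cccc(CNc2ncnc3ccccc23)c1` carries a 3-chlorophenyl. In this assay compound 3 reaches only a limit of the assay, > 50000 nM, so no number is known for it. Against the two methoxy analogues the steps read an at least 1.6-fold higher number from compound 1 to compound 3 (0.21 log units; that floor lies within the scatter) and an at least 1.7-fold higher number from compound 2 to compound 3 (0.23 log units; that floor lies within the scatter), both floors sitting within the scatter, so compound 3 stands at the weak end of a weak series, as the limit of > 50000 nM in this assay, at which 1 of the 3 values shown sits, records.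

Compound 4 `O=C(Nc1ccc([N+](=O)[O-])cc1)Nc1cccc(CNc2ncnc3ccccc23)c1` is the next member: 4-nitrophenyl in place of 3-chlorophenyl on an amide-type nitrogen. Among the measured compounds shown here, none of the measured steps tests a nitrophenyl, and the steps among the three known compounds are all within the scatter. The expectation for compound 4 is therefore a value near the limit where compound 3 sits, with a good chance that only a limit is again reported. The step from the limit of compound 3 is estimated as a number no higher from compound 3 to compound 4 (the limit leaves the size open). For compound 4 the estimate in this assay is 50000 nM, with a range from 20000 nM to 120000 nM.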

Compound 4, half-maximal inhibitory concentration: > 50000 nM
Compound 4: only a limit was reported (the forecaster's own chance of this, stated with the estimate: 55%); the middle value lies on the limit itself.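

Compound 4 is the second compound in this assay for which only a limit is known, so a limit at this amide-type nitrogen is no longer tied to the 3-chlorophenyl alone: the limit of > 50000 nM in this assay, at which 2 of the 4 values shown sit. Nitro in place of methoxy on an aromatic carbon gives an at least 1.7-fold higher number from compound 2 to compound 4 (0.23 log units; that floor lies within the scatter), and 4-nitrophenyl in place of 2-methoxyphenyl gives an at least 1.6-fold higher number from compound 1 to compound 4 (0.21 log units; that floor lies within the scatter), so neither floor separates compound 4 from the methoxy analogues beyond the scatter. The step between compound 3 and compound 4 cannot be read, so the two groups cannot be ranked against each other.

Going by these compounds, whether any group on this nitrogen gives a value clearly apart from those of compound 1 and compound 2 stays open, for example a 4-aminophenyl, a 4-carboxyphenyl or a cyclohexyl in place of the aromatic ring. Also open, on these data alone, is how far the true values of compound 3 and compound 4 lie from their shared limit, and so whether the chloro and nitro compounds differ at all from each other.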